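Alkynyl uracils: Vero cytotoxicity, silyl to ethyl

The source may hold more compounds than are shown below. What is called first, only, known or untested is meant among the compounds shown, and "the series" means these compounds.

Measured so far:
compound 1 `CCCCC#Cc1c[nH]c(=O)[nH]c1=O` gives 253000 nM
compound 2 `C[Si](C)(C)C#Cc1c[nH]c(=O)[nH]c1=O` gives 270000 nM
compound 3 `O=c1[nH]c(=O)n([C@@H]2O[C@H](CO)[C@@H](O)[C@H]2O)cc1C#Cc1ccccc1` gives 78400 nM

The read-out throughout is an ADME assay on Vero cells (Chlorocebus sabaeus) for cytotoxicity, read by MTT assay; a lower number here means that less compound is tolerated, a higher number that more compound is tolerated. Compound 2 holds the highest number of the three, but compound 1 sits within the scatter of it, and only compound 3, whose number is lower by a margin beyond the scatter, stands clearly apart. Compound 3 carries a sugar on the shared core where compounds 1 and 2 carry a ring hydrogen, so its gap is not a step that can be read against the alkyne substituent alone.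

Compound 4 `CCC#Cc1c[nH]c(=O)[nH]c1=O` is not yet measured. It differs from compound 2 as follows: a group of 2 heavy atoms (2 carbon; no ring) in place of a group of 4 heavy atoms (3 carbon, 1 silicon; no ring), on a triple-bonded carbon.

Among the measured compounds shown here, the one step that bears on this change is a 1.1-fold higher number from compound 1 to compound 2 (0.03 log units; within the scatter), an exchange of one four-atom group for another on the same triple-bonded carbon without a change beyond the scatter. The step to compound 4 exchanges the same place for a shorter chain, ethyl; the two measured chain variants of this core give numbers that do not separate, so no step beyond the scatter is expected in this assay.

Compound 4 is therefore estimated at 260000 nM, with a range of 130000 nM to 520000 nM, meaning an expected step of a 1.0-fold lower number from compound 2 to compound 4 (0.02 log units; within the scatter).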

Compound 4, half-maximal cytotoxic concentration: 263000 nM
For compound 4 the middle estimate is 1.0-fold (0.00 log units) below the measured one; the measured number falls inside the stated range.
By their numbers in this assay, from the lowest: compound 3; then compounds 1, 4 and 2 (each within the scatter of the next).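

In this assay, the ethyl of compound 4 takes the place of the group of 4 heavy atoms holding silicon on the triple-bonded carbon with no change beyond the scatter (a 1.0-fold lower number from compound 2 to compound 4 (0.01 log units; within the scatter)), so at this place silicon is not required for a number of this size among the compounds shown. Chain length gives the same reading (a 1.0-fold higher number from compound 1 to compound 4 (0.02 log units; within the scatter)): the two all-carbon chains do not separate, and the three compounds with a ring hydrogen in place of the sugar now form one group within the scatter in this assay, with three different groups on the triple-bonded carbon. Nothing available gives a reason for this lack of separation.

Still open, from the compounds shown here alone, is whether the flat reading holds for groups of another kind on the same triple-bonded carbon, such as a chain ending in an amine or a carboxylic acid. Compound 3 differs from these three compounds in more than one place, so the separate contributions of its sugar and its phenyl ring to its gap cannot be read.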